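The source may report more compounds than this note shows. Statements on the series, on what has been measured and on what is new or still open speak of the compounds shown alone.

Working notes on the series.

Among the measured compounds shown here, in a functional assay on PANC-1 cells (Homo sapiens) for inhibition, read by MTT assay, with a stated time of 24 h, tested at 10 uM (on this read-out lower numbers stand for less inhibition and higher numbers for more inhibition at the one concentration tested (going by the name of the read-out)), compound 1 `CC(C)=CCOc1cc(=O)n(CCCO)c2c1CC(CC=C(C)C)C(C)(C)C2` gives 7.5% and stands highest of the three numbers measured so far, though each of the others lies within the scatter of it. Compound 2 `CC(C)=CCC1Cc2c(OCCCNS(=O)(=O)c3ccc(Br)cc3)cc(=O)n(CCCO)c2CC1(C)C` gives 3.7% in this assay, and compound 3 `CC(C)=CCC1Cc2c(OCCCOc3ccc([N+](=O)[O-])cc3)cc(=O)n(CCCO)c2CC1(C)C` gives 0%. The step of a number 7.5 percentage points lower from compound 1 to compound 3 (within the scatter) and the step of a number 3.7 percentage points lower from compound 2 to compound 3 (within the scatter) are both within the scatter, so the three measured compounds show no difference that can be relied upon; the whole series sits near the bottom of the read-out.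

Compound 4 `COc1ccc(NC(=O)Oc2cc(=O)n(CCCO)c3c2CC(CC=C(C)C)C(C)(C)C3)cc1` has not yet been measured. It differs from compound 1 in one place: (4-methoxyphenyl)carbamoyl in place of 3-methylbut-2-en-1-yl on an oxygen on an aromatic ring. For the measured compounds named here, the only measured step that touches the same part of the molecule is the one from compound 1 to compound 3, which alters the chain on that oxygen and stays within the scatter. Going by the values given here, no measured compound carries a carbamoyl group on that oxygen, so the data give no direct guide to this change. With every measured value low and every measured step within the scatter, the expectation for compound 4 in this assay is a step of a number 0.5 percentage points lower from compound 1 to compound 4 (within the scatter) that does not exceed the scatter. Compound 4 is estimated at 7%, within a range from 0% to 20%.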

Compound 4, a percentage reported as inhibition, at one concentration (the size of the read-out at that concentration, not a potency): 0%
The estimate for compound 4 lay 7 percentage points above the measured number; measured number inside the range.
By their numbers in this assay, from the lowest: compounds 3, 4, 2 and 1 (each within the scatter of the next).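

In this assay, (4-methoxyphenyl)carbamoyl in place of 3-methylbut-2-en-1-yl on an oxygen on an aromatic ring gives a number 7.5 percentage points lower from compound 1 to compound 4 (within the scatter), so this change cannot be told apart from no change at all. The earlier compounds shown here held only chains joined to this oxygen through a saturated carbon, whereas compound 4 puts a carbamoyl group directly on it and brings in a six-membered aromatic ring of carbon only and a hydrogen-bond donor, and even this larger change in the type of link leaves the read-out within the scatter of compound 1. No measurement is available that would account for this flat result at the position.

From the compounds shown here alone, it remains open whether a group such as a primary amine or a carboxylic acid at the end of the chain on this oxygen would give a number beyond the scatter of compound 1. Also open, going by these compounds, is whether an amine in place of the hydroxyl group shared by all four compounds would separate any of them in this assay.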